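The compounds below may be only part of what the source reports. "The series", "measured", "known", "first", "only" and "open" are said of these compounds alone.

Working notes on the series. Among the compounds with values here, in an assay on CHO cells for agonist activity at 5-hydroxytryptamine receptor 1D (Homo sapiens), read by GTPgammaS binding (on this read-out higher numbers stand for an effect only at larger amounts of compound and lower numbers for an effect already at smaller amounts), compound 3 `c1ccc2c(c1)CCC2NCC1CCN(CCCc2c[nH]c3ccc(-n4cnnc4)cc23)CC1` gives 1.3 nM, the lowest of the three numbers so far: compound 2 `c1ccc(CNCC2CCN(CCCc3c[nH]c4ccc(-n5cnnc5)cc34)CC2)cc1` gives 5.6 nM and compound 1 `NC(=O)OC[C@H](NC1CCN(CCCc2c[nH]c3ccc(-n4cnnc4)cc23)CC1)c1ccccc1` gives 9.3 nM. Within the data shown here, the one measured step, a 4.3-fold lower number from compound 2 to compound 3 (0.63 log units; beyond the scatter), is the only change of the amine substituent. Compound 4 `C[C@H](NC1CCN(CCCc2c[nH]c3ccc(-n4cnnc4)cc23)CC1)c1ccccc1` differs from compound 3 by (1-phenylethyl)amino in place of ((2,3-dihydro-1H-inden-1-yl)amino)methyl on a saturated ring carbon. This undoes the gain seen in a 4.3-fold lower number from compound 2 to compound 3 (0.63 log units; beyond the scatter) and moves toward compound 1, which also bears a phenyl-carrying amine and gives 9.3 nM. A moderately higher number than for compound 3 is therefore expected, roughly in the range of compound 1 and compound 2. Compound 4 is estimated at 6 nM (range 2 nM to 20 nM), which means an expected step of a 4.6-fold higher number from compound 3 to compound 4 (0.66 log units; beyond the scatter).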

Compound 4, half-maximal effective concentration: 12 nM
Beside the measured number, compound 4's estimate is 2.0-fold (0.30 log units) below it, within the range that was stated.
By their numbers in this assay, from the lowest: compound 3; then compounds 2, 1 and 4 (each within the scatter of the next, the first and the last beyond it).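

Placing (1-phenylethyl)amino on the saturated ring carbon in place of ((2,3-dihydro-1H-inden-1-yl)amino)methyl gives a 9.2-fold higher number from compound 3 to compound 4 (0.97 log units; beyond the scatter), and in place of (benzylamino)methyl it gives a 2.1-fold higher number from compound 2 to compound 4 (0.33 log units; beyond the scatter), so compound 2 and compound 3 both keep lower numbers than compound 4. Hydrogen in place of carbamoyloxy on the saturated chain carbon gives a 1.3-fold higher number from compound 1 to compound 4 (0.11 log units; within the scatter), so carbamoyloxy makes no difference beyond the scatter in this pair. From the compounds shown here alone, whether a pyridine ring in place of the phenyl ring, or a carboxylic acid in place of carbamoyloxy, would leave the number unchanged stays open. No evidence on the cause of these steps is available.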